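Removing the phenyl from compound 3: a flat step expected

The source may report more compounds than this note shows. Statements on the series, on what has been measured and on what is new or still open speak of the compounds shown alone.

Of the compounds shown here, three sharing one core have been measured in a functional assay on FTC-133 cells (Homo sapiens) for cytotoxicity, read by MTT assay, with a stated time of 24 h; on this read-out lower numbers stand for stronger inhibition and higher numbers for weaker inhibition. Compound 1 `CN1O[C@@H](n2cc(-c3ccccc3)nn2)C[C@@H]1CO` gives 6030 nM. Compound 2 `CN1O[C@@H](n2ccnn2)C[C@@H]1CO` carries hydrogen where compound 1 carries phenyl; in this assay compound 2 gives 6530 nM. Compound 3 `CN1O[C@H](n2cc(-c3ccccc3)nn2)C[C@@H]1CO` gives 6330 nM. Compound 3 stands second highest of these three numbers, yet all three lie so close together that none can be told apart from the others within the usual scatter.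

Two steps connect the measured values. From phenyl to hydrogen: a 1.1-fold higher number from compound 1 to compound 2 (0.03 log units; within the scatter). Between the two drawn configurations: a 1.0-fold higher number from compound 1 to compound 3 (0.02 log units; within the scatter); this second step rests on (the fact that compounds 1 and 3 differ only in the configuration as drawn).

Compound 4 `CN1O[C@H](n2ccnn2)C[C@@H]1CO` has not yet been measured. It differs from compound 3 in one place: hydrogen in place of phenyl on an aromatic carbon. This is the same exchange as that between compound 1 and compound 2, carried out on the other configuration of the saturated ring carbon.

Since the matching step from compound 1 to compound 2 stayed within the scatter, no change beyond the scatter is expected in this assay from compound 3 to compound 4, in either direction. The step expected from this exchange is a 1.1-fold higher number from compound 3 to compound 4 (0.02 log units; within the scatter). Compound 4 is therefore estimated at 6700 nM, with a range from 3500 nM to 13000 nM.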

Compound 4, half-maximal inhibitory concentration: 6300 nM
The estimate for compound 4 lay 1.1-fold (0.03 log units) above the measured number; measured number inside the range.
By their numbers in this assay, from the lowest: compounds 1, 4, 3 and 2 (each within the scatter of the next).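

In this assay, hydrogen in place of phenyl on the aromatic carbon gives a 1.0-fold lower number from compound 3 to compound 4 (0.00 log units; within the scatter), so this exchange now stays within the scatter on both drawn configurations of the saturated ring carbon: the same change on two cores in this assay, a 1.1-fold higher number (0.03 log units; within the scatter) from compound 1 to compound 2 and a 1.0-fold lower number (0.00 log units; within the scatter) from compound 3 to compound 4, 1.1-fold (0.04 log units) apart, within the scatter of two such steps

The configuration at that carbon can now also be read without the phenyl, and it gives a 1.0-fold lower number from compound 2 to compound 4 (0.02 log units; within the scatter), so with hydrogen on the aromatic carbon, as with phenyl, the two drawn forms cannot be told apart: the fact that compounds 2 and 4 differ only in the configuration as drawn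

All four compounds are thus joined by steps that lie within the scatter, and neither the phenyl nor this one configuration separates them in this set.

Phenyl and hydrogen are the only groups shown on this aromatic carbon, so it remains open whether an amine, a carboxylic acid or a longer carbon chain there would move the number beyond the scatter. From the compounds shown here alone, the second stereocentre of the shared core is drawn the same way in all four compounds, so what its opposite configuration would do also remains open.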